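Opening a Five-Membered Ring: From Compound 2 to Compound 4

This account rests on a few compounds, and the source may have more. Where it says the series, first, only, none or still open, it means among the compounds named here.

Three amides of a shared core were made: compound 1 `O=C(CCCCC1CCSS1)Nc1ccccn1`, compound 2 `O=C(CCCCC1CCSS1)Nc1ccc(Cl)cn1` and compound 3 `O=C(CCCCC1CCSS1)Nc1ccc(Br)cn1`. Among the compounds with values here, in a functional assay on PC-3 cells (Homo sapiens) for inhibition, read by MTT assay, with a stated time of 24 h, tested at 1 ug/mL (on this read-out higher numbers stand for more inhibition of growth at the one concentration tested and lower numbers for less inhibition of growth), compound 2 gives 2%, the only number reported. In this assay compound 1 gives "not determined" (no result reported) and compound 3 gives "not determined" (no result reported), so no result was reported for either of them. Compound 2 therefore stands alone, with weak inhibition of growth at the single concentration tested.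

Compound 4 `O=C(CCCCC(S)CCS)Nc1ccc(Cl)cn1` differs from compound 2 in one place: a group of 5 heavy atoms (3 carbon, 2 sulfur; no ring) in place of a group of 5 heavy atoms (3 carbon, 2 sulfur; one five-membered non-aromatic ring with 2 hetero atoms), on a saturated chain carbon, four bonds along the chain from a carbonyl carbon. The 1,3-disulfanylpropyl group enters on a saturated chain carbon, four bonds along the chain from the carbonyl carbon.

Within the data shown here, no step between measured compounds is available, so the expectation rests on compound 2 alone. The step of a number 3 percentage points higher from compound 2 to compound 4 (within the scatter) is expected to stay within the scatter, in no particular direction. Compound 4 is estimated to give 5% in this assay, within a range from -8% to 18%.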

Compound 4, percent growth inhibition at one concentration: 0.89%
Estimate against measurement, compound 4: 4.1 percentage points above; the range from low to high includes it.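

Going from the closed ring to the open 1,3-disulfanylpropyl group gives a number 1.1 percentage points lower from compound 2 to compound 4 (within the scatter) in this assay. Within the data shown here, this is the first sign that, at this position, opening the ring and adding hydrogen-bond donors leaves the read-out where it was, with growth inhibition still weak at the one concentration tested. Nothing available explains this result.

From the compounds shown here alone, whether any other group here, such as a carboxylic acid, an amine or a longer chain, would move the number beyond the scatter remains open.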